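A few compounds are considered here, and "the series" means these few. Any claim that something is new, unique, unknown or untested is made for them only; others in the source may bear on it.

Measured so far in a functional assay on HT-29 cells (Homo sapiens) for inhibition, read by CCK-8 assay, with a stated time of 24 h; on this read-out lower numbers stand for stronger inhibition and higher numbers for weaker inhibition:
- Compound 1 `Cc1cccc(-n2cc(-c3ccc(/C=C4\C(=O)Nc5ccccc54)cc3)nn2)c1`: 3940 nM
- Compound 2 `Cc1ccccc1-n1cc(-c2ccc(C=C3C(=O)Nc4ccc(F)cc43)cc2)nn1`: 5870 nM
- Compound 3 `Cc1cccc(-n2cc(-c3ccc(/C=C4\C(=O)Nc5ccc(F)cc54)cc3)nn2)c1`: 7320 nM

Nothing sets compound 3 apart within this small set, as its value lies within the scatter of the values of both compound 1 and compound 2. The next compound, compound 4 `O=C1Nc2ccc(F)cc2/C1=C/c1ccc(-c2cn(-c3cccc(Cl)c3)nn2)cc1`, has not yet been measured. It differs from compound 3 by a single change, (chloro in place of methyl on an aromatic carbon), which is chloro in place of methyl on an aromatic carbon, turning 3-methylphenyl into 3-chlorophenyl.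

Among the compounds with values here, only one measured step connects compounds that differ in one place: a 1.9-fold higher number from compound 1 to compound 3 (0.27 log units; within the scatter). That step is fluoro in place of hydrogen on an aromatic carbon, a different change from the one at issue, so it offers only indirect guidance. Within the data shown here, no measurement yet shows what replacing the methyl group does. Among the measured compounds shown here, the three measured values lie close together, and the one measured step stays within the scatter, so no step beyond the scatter is expected in this assay, in either direction. The estimate amounts to a 1.2-fold lower number from compound 3 to compound 4 (0.09 log units; within the scatter), which is expected to remain within the scatter. For compound 4 the expected value is 6000 nM, with an estimated range from 2800 nM to 12000 nM.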

Compound 4, half-maximal inhibitory concentration: 10500 nM
Compound 4: middle estimate off by 1.8-fold (0.24 log units), on the low side, within the range that was stated.
By their numbers in this assay, from the lowest: compounds 1, 2, 3 and 4 (each within the scatter of the next, the first and the last beyond it).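

Within the data shown here, replacing the methyl of the 3-methylphenyl group of compound 3 with chloro gives the first direct reading at this position, an aromatic carbon meta to a large group: in this assay the change amounts to a 1.4-fold higher number from compound 3 to compound 4 (0.16 log units; within the scatter) and so does not separate the two groups. With the fluoro kept on the shared core, 3-methylphenyl and 3-chlorophenyl therefore cannot be told apart in this read-out, although one heavy atom has been exchanged for another, with no hydrogen-bond donors or acceptors on either side. Nothing at hand offers an explanation for what is seen at this position.

From the compounds shown here alone, what stays open is whether any other group at this place on the ring would move the value beyond the scatter, for instance an amine, a carboxylic acid or a longer chain such as propyl, since methyl and chloro span only a narrow choice. Going by these compounds, it is also open whether chloro would give the same picture on the core of compound 1, which carries hydrogen in place of the fluoro.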